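Extending the methoxy of compound 3 into an oxolanylmethoxy

The compounds below may be only part of what the source reports. "The series", "measured", "known", "first", "only" and "open" are said of these compounds alone.

Compound 1, `CNC(=O)c1cccn2cc(-c3cccc(-c4cncc(OC)c4)c3)nc12`, gives 5500 nM in a physicochemical assay for solubility, in phosphate buffer, with a stated time of 24 h, at pH 7.4; on this read-out higher numbers stand for higher solubility and lower numbers for lower solubility.
Compound 2, `COc1cncc(-c2cccc(-c3cn4cccc(C(=O)N(C)C)c4n3)c2)c1`, gives 10000 nM in this assay.
Compound 3, `COc1cncc(-c2cccc(-c3cn4ccnc(C(N)=O)c4n3)c2)c1`, gives 10000 nM in this assay.

Among the three measured compounds, compound 3 stands level with compound 2 at the digits reported, and the two together sit at the highest value of the set; the gap to compound 1 is within the scatter, so no order can be read between any of them.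

Compound 4, `NC(=O)c1nccn2cc(-c3cccc(-c4cncc(OC[C@H]5CCCO5)c4)c3)nc12`, is not yet measured. It differs from compound 3 by oxolan-2-yl in place of hydrogen on a saturated chain carbon bound to an oxygen on an aromatic ring, so that the methoxy of compound 3 becomes a (oxolan-2-yl)methoxy.

For the measured compounds named here, the single measured step, a 1.8-fold higher number from compound 1 to compound 2 (0.26 log units; within the scatter), concerns a methyl on an amide-type nitrogen on the shared core and does not touch the aromatic methoxy; it gives no guide to the present change. Nothing measured here speaks to extending the methoxy. The step from compound 3 to compound 4 is therefore expected to lie within the scatter, a 1.1-fold lower number from compound 3 to compound 4 (0.05 log units; within the scatter). Compound 4 is estimated at 9000 nM, within a range from 3500 nM to 20000 nM.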

Compound 4, solubility: 40000 nM
For compound 4 the middle estimate is 4.4-fold (0.65 log units) below the measured one; the whole stated range lies below it.
By their numbers in this assay, from the lowest: compounds 1, 2 and 3 (each within the scatter of the next); then compound 4.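

In this assay, the change at this position produces the only step among the compounds shown that lies beyond the scatter: oxolan-2-yl in place of hydrogen on a saturated chain carbon bound to an oxygen on an aromatic ring gives a 4.0-fold higher number from compound 3 to compound 4 (0.60 log units; beyond the scatter). For the compounds shown here, the earlier compounds differ only at the amide end of the shared core and stay within the scatter of one another, so this is the first sign that the read-out can move with what is carried on this oxygen. Nothing in the available evidence explains the rise in the number on going from methoxy to (oxolan-2-yl)methoxy.

As far as these compounds go, it remains open whether the step depends on the five-membered ring, on its ring oxygen or on the defined stereocentre, a question that the opposite stereoisomer, a tetrahydropyranylmethoxy or an open 2-methoxyethoxy chain would address. From the compounds shown here alone, it is equally open whether an amine at the end of the chain would move the number in the same direction, or whether the same extension would give a similar step on the dimethylamide of compound 2.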